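This account rests on a few compounds, and the source may have more. Where it says the series, first, only, none or still open, it means among the compounds named here.

Measured in a functional assay on Huh-7 cells (Homo sapiens) for cytotoxicity, with a stated time of 48 h; a lower number here means a stronger inhibitor, a higher number a weaker inhibitor:
- compound 1 `N#Cc1ccc(-c2cncc(-c3cc4ccc(O)cc4[nH]3)c2)cc1`: 1500 nM
- compound 2 `Oc1ccc(-c2cncc(-c3cc4ccc(O)cc4[nH]3)n2)cc1`: 5000 nM

Of these two compounds, compound 2 has the higher number and so is the weaker inhibitor, with a gap to compound 1 that lies beyond the usual scatter. Compound 3 `N#Cc1ccc(-c2cncc(-c3cc4ccc(O)cc4[nH]3)n2)cc1`, not yet measured, keeps the core of compound 2 but carries cyano in place of hydroxy on an aromatic carbon, para to a large group: cyano in place of hydroxy on an aromatic carbon. Going by the values given here, no measured pair shows this change alone. Among the compounds with values here, the only guide is compound 1, which also bears 4-cyanophenyl on a different core and gives 1500 nM. A moderate move toward a lower number in this assay is therefore expected, though with little certainty. The expected change is a 2.3-fold lower number from compound 2 to compound 3 (0.36 log units; beyond the scatter). For compound 3 the estimated value is 2200 nM, with an expected range from 700 nM to 7000 nM.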

Compound 3, half-maximal inhibitory concentration: 7000 nM
Estimate against measurement, compound 3: 3.2-fold (0.50 log units) below, and the stated range covers the measured number.
By their numbers in this assay, from the lowest: compound 1; then compounds 2 and 3 (each within the scatter of the next).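

On the core of compound 2, replacing 4-hydroxyphenyl with 4-cyanophenyl gives a 1.4-fold higher number from compound 2 to compound 3 (0.15 log units; within the scatter) in this assay. On this core, then, the place on the six-membered carbon ring can hold hydroxy or cyano with no readable difference in this assay. Carrying 4-cyanophenyl does not by itself give a shared number, since compound 1 gives 1500 nM and compound 3 gives 7000 nM on their different cores. Nothing measured here accounts for the lack of a readable difference on this core. Still open, going by these compounds, is whether an amine or a carboxylic acid at this same place would leave the number within the scatter, and whether hydroxy and cyano would also match on the core of compound 1.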